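The compounds below may be only part of what the source reports. "The series", "measured", "known", "first", "only" and "open" are said of these compounds alone.

Compound 2 `COc1cc2c(cc1OC)C(CC(=O)N1CCCCC1)CC2` gives 18.8% in a functional assay on the whole organism (strain Wistar) for inhibition, with Rattus norvegicus as the target, read by paw edema, with stated times of 60 min and 1 h, at a dose of 100 mg/kg by the oral route; on this read-out higher numbers stand for more inhibition at the one dose given (going by the name of the read-out) and lower numbers for less inhibition. Compound 1 `COc1cc2c(cc1OC)C(CC(N)=O)CC2` gives 18.8% in the same assay, and the step of no change at the digits printed from compound 1 to compound 2 (within the scatter) shows that replacing amino with piperidin-1-yl on the carbonyl carbon left the read-out unchanged within the scatter. Compound 3 `COc1cc2c(cc1OC)C(CC(=O)N1CCOCC1)CC2` differs from compound 2 in one place: morpholin-4-yl in place of piperidin-1-yl on a carbonyl carbon. Among the measured compounds shown here, only that one measured step speaks to a change at the carbonyl carbon, and it was flat, so compound 3 is expected to show no step beyond the scatter, a number 0.8 percentage points lower from compound 2 to compound 3 (within the scatter). Compound 3 is therefore estimated at 18%, within a range from 8% to 30%.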

Compound 3, a percentage reported as inhibition, in the whole organism at one dose (the size of the read-out at that dose, not a potency): 15.6%
The estimate for compound 3 lay 2.4 percentage points above the measured number, and the stated range covers the measured number.
By their numbers in this assay, from the lowest: compounds 3, 1 and 2 (each within the scatter of the next).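

In this assay, morpholin-4-yl on the carbonyl carbon gives a number 3.2 percentage points lower from compound 2 to compound 3 (within the scatter) and a number 3.2 percentage points lower from compound 1 to compound 3 (within the scatter) in the two comparisons. The flat result now extends to a group with a second hetero atom in its ring and a hydrogen-bond acceptor, so amino, piperidin-1-yl and morpholin-4-yl all read level at this position. Nothing measured here offers an explanation for this flat result. The compounds shown leave open whether piperazin-1-yl or hydroxyl on the carbonyl carbon, or a longer chain carrying that carbonyl, would move the read-out beyond the scatter.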